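The source may report more compounds than this note shows. Statements on the series, on what has been measured and on what is new or still open speak of the compounds shown alone.

Measured in a functional assay on PC-3 cells (Homo sapiens) for cytotoxicity, read by MTT assay, with a stated time of 24 h; on this read-out higher numbers stand for weaker inhibition and lower numbers for stronger inhibition:
- compound 1 `COc1ccc(/C=C2\CN(Cc3cn(Cc4cccc(Cl)c4)nn3)C/C(=C\c3ccc(OC)cc3)C2=O)cc1`, 32500 nM
- compound 2 `Cc1ccc(/C=C2\CN(Cc3cn(Cc4cccc(Cl)c4)nn3)C/C(=C\c3ccc(C)cc3)C2=O)cc1`, 29300 nM

Compound 1 stands level with compound 2, their two values lying within the scatter of each other. Still unmeasured is compound 3 `COc1ccc(/C=C2\CN(Cc3cn(Cc4ccccc4Cl)nn3)C/C(=C\c3ccc(OC)cc3)C2=O)cc1`, which differs from compound 1 by 2-chlorophenyl in place of 3-chlorophenyl on a saturated chain carbon bound to an aromatic nitrogen, with 2-chlorophenyl in place of 3-chlorophenyl on a saturated chain carbon bound to an aromatic nitrogen. Among the measured compounds shown here, no measured pair shows this change. In this assay no step beyond the scatter is therefore expected, and no direction is favoured. The expected step is a 1.1-fold lower number from compound 1 to compound 3 (0.03 log units; within the scatter). For compound 3 the estimated value is 30000 nM, with an expected range of 14000 nM to 60000 nM.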

Compound 3, half-maximal inhibitory concentration: 36300 nM
Estimate against measurement, compound 3: 1.2-fold (0.08 log units) below; measured number inside the range.
By their numbers in this assay, from the lowest: compounds 2, 1 and 3 (each within the scatter of the next).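

In this assay the swap of 3-chlorophenyl for 2-chlorophenyl on a saturated chain carbon bound to an aromatic nitrogen gives a 1.1-fold higher number from compound 1 to compound 3 (0.05 log units; within the scatter) and so leaves the number inside the scatter. Among the compounds shown here, compounds 1 and 2 both carry 3-chlorobenzyl, so this pair is the first reading of a change at this place, and the two chlorophenyl isomers cannot be told apart here. No measurement is at hand that would explain this result.

As far as these compounds go, whether a group other than chlorobenzyl at this place, such as unsubstituted benzyl or a longer chain ending in an amine, would move the number stays open. So does whether 2-chlorophenyl behaves the same way on the core of compound 2.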